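Fluoropyridyl for fluorophenyl, carried onto a second core

The source may report more compounds than this note shows. Statements on the series, on what has been measured and on what is new or still open speak of the compounds shown alone.

Measured compounds:
compound 1, `COc1ccc(/C=C/C(=O)c2ccccc2-c2ccc(F)cc2)cc1`, gives 61 nM in a functional assay on SW480 cells (Homo sapiens) for antiproliferative activity, read by sulforhodamine B assay, with a stated time of 48 h; on this read-out lower numbers stand for stronger inhibition and higher numbers for weaker inhibition
compound 2, `COc1ccc(/C=C/C(=O)c2ccccc2-c2ccc(F)nc2)cc1`, gives 330 nM in this assay
compound 3, `COc1ccc(C(=O)/C=C/c2ccccc2-c2ccc(F)cc2)cc1OC`, gives 8300 nM in this assay

Compound 2 differs from compound 1 by 6-fluoropyridin-3-yl in place of 4-fluorophenyl on an aromatic carbon. This change brings a 5.4-fold higher number from compound 1 to compound 2 (0.73 log units; beyond the scatter). Compound 3 stands highest of the three measured numbers, well beyond the scatter from both compound 1 and compound 2; the difference between the core of compound 3 and the core of compound 1 is not broken down here.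

Compound 4, `COc1ccc(C(=O)/C=C/c2ccccc2-c2ccc(F)nc2)cc1OC`, is not yet measured. It differs from compound 3 by 6-fluoropyridin-3-yl in place of 4-fluorophenyl on an aromatic carbon, the same change as from compound 1 to compound 2, at a place described in the same words. Among the compounds with values here, for compound 4 in this assay a step of a 3.6-fold higher number from compound 3 to compound 4 (0.56 log units; beyond the scatter) is expected, in the same direction as a 5.4-fold higher number from compound 1 to compound 2 (0.73 log units; beyond the scatter), which is the single earlier instance of this change. The earlier instance sits on a different core and the starting number of compound 3 is already high, so the range is kept wide and a limit instead of a number is possible. Compound 4 is expected near 30000 nM, between 12000 nM and 80000 nM.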

Compound 4, half-maximal inhibitory concentration: 15000 nM
The estimate for compound 4 lay 2.0-fold (0.30 log units) above the measured number; low and high end bracket the measured number.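

In this assay, within the data shown here, the exchange of 4-fluorophenyl for 6-fluoropyridin-3-yl gives a 1.8-fold higher number from compound 3 to compound 4 (0.26 log units; within the scatter) and so, on the core of compound 3, produces no step that can be read beyond the scatter. The size of the step on the core of compound 1 did not carry over to the core of compound 3: the same change on two cores in this assay, a 5.4-fold higher number (0.73 log units; beyond the scatter) from compound 1 to compound 2 and a 1.8-fold higher number (0.26 log units; within the scatter) from compound 3 to compound 4, 3.0-fold (0.48 log units) apart, beyond the scatter of two such steps. Among these compounds, this rests on a single pair per core, so it shows only that the step is not a constant across these two cores, and it does not show what in the cores sets the gap or how the change would read on a third core.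

Which of the differences between the core of compound 1 and the core of compound 3 accounts for the gap remains open. Also open, from the compounds shown here alone, is how other groups would read on this aromatic carbon, for example a pyridine ring without fluorine or an amine-bearing pyridine ring.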